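This account rests on a few compounds, and the source may have more. Where it says the series, first, only, none or still open, it means among the compounds named here.

In a functional assay on HepG2 cells (Homo sapiens) for cytotoxicity, read by MTT assay, with a stated time of 72 h (a higher number here means a weaker inhibitor, a lower number a stronger inhibitor), compound 3 `CCN1CCN(CCC(=O)Nc2ccc3[nH]c(-c4ccc(C)cc4)nc3c2)CC1` reads 14600 nM, the higher of the two numbers available. Compound 2 `Cn1cccc1-c1nc2cc(NC(=O)CCl)ccc2[nH]1` reads 1800 nM, the lower of the two. Compound 1 `Cn1cccc1-c1nc2cc(NC(=O)CCCl)ccc2[nH]1` gives > 50000 nM, which is a limit and not a number.

Compound 4 `CCN1CCN(CCC(=O)Nc2ccc3[nH]c(-c4cccn4C)nc3c2)CC1` differs from compound 3 in one place: 1-methyl-1H-pyrrol-2-yl in place of 4-methylphenyl on an aromatic carbon, with 1-methyl-1H-pyrrol-2-yl in place of 4-methylphenyl on an aromatic carbon. Among the measured compounds shown here, the only measured step, an at least 27-fold lower number from compound 1 to compound 2 (1.44 log units; beyond the scatter), is large, but it lies in the chloro-bearing amide chain and not at this carbon. Its size is also bounded by the limit of > 50000 nM in this assay, at which 1 of the 3 values shown sits. For the measured compounds named here, compounds 1 and 2 already carry the entering group, but their amide chains differ from that of compound 3, so no measured pair isolates this exchange.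

From the compounds shown here alone, no step beyond the scatter is therefore expected in this assay, and either direction stays open, with compound 3 at 14600 nM as the anchor. The estimated step is a 1.2-fold lower number from compound 3 to compound 4 (0.09 log units; within the scatter), expected to stay within the scatter. For compound 4 the expected value is 12000 nM, with an estimated range of 4000 nM to 35000 nM.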

Compound 4, half-maximal inhibitory concentration: > 50000 nM
Compound 4 gave a limit, no number; the forecaster's own chance of this, stated with the estimate: 10%; middle value at least 4.1-fold (0.61 log units) from the limit.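

In this assay, among the compounds shown here, the first measured exchange on the aromatic carbon between two ring nitrogen atoms, 1-methyl-1H-pyrrol-2-yl in place of 4-methylphenyl, gives an at least 3.4-fold higher number from compound 3 to compound 4 (0.53 log units; beyond the scatter), so the read-out responds to this position with the chain of compound 3 held. For the compounds shown here, on the chain, (4-ethylpiperazin-1-yl)methyl in place of chloro gives an at least 27-fold higher number from compound 2 to compound 4 (1.44 log units; beyond the scatter), which leaves compound 2 as the only compound carrying 1-methyl-1H-pyrrol-2-yl that gives a number. Compound 4 gives a limit and not a number, and the step from compound 1 to compound 4 cannot be read: the limit of > 50000 nM in this assay, at which 2 of the 4 values shown sit.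

From the compounds shown here alone, whether the exchange at this carbon runs the same way on the chloro-bearing chain of compound 2 stays open. Also open, going by these compounds, is whether a morpholine in place of 4-ethylpiperazin-1-yl, or an unsubstituted phenyl at this carbon, would give a number in this assay.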